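Replacing 2-methoxybutyl with (furan-3-yl)carbonyl on a shared core

The source may report more compounds than this note shows. Statements on the series, on what has been measured and on what is new or still open speak of the compounds shown alone.

Three compounds built on one core sit close together in a functional assay on HeLa cells (Homo sapiens) for cytotoxicity, read by MTT assay; on this read-out higher numbers stand for weaker inhibition and lower numbers for stronger inhibition: compound 1 `CC(C)=CC[C@@H](OC(=O)CCO)C1=CC(=O)c2c(O)ccc(O)c2C1=O` gives 67600 nM, compound 2 `COCCO[C@H](CC=C(C)C)C1=CC(=O)c2c(O)ccc(O)c2C1=O` gives 62400 nM, and compound 3 `CCC(CO[C@H](CC=C(C)C)C1=CC(=O)c2c(O)ccc(O)c2C1=O)OC` gives 63500 nM. Compound 3 thus stands within the scatter of both others, and the three cannot be ranked.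

The next compound, compound 4 `CC(C)=CC[C@@H](OC(=O)c1ccoc1)C1=CC(=O)c2c(O)ccc(O)c2C1=O`, carries (furan-3-yl)carbonyl in place of the 2-methoxybutyl of compound 3, on an oxygen on a saturated carbon: (furan-3-yl)carbonyl in place of 2-methoxybutyl on an oxygen on a saturated carbon.

For the measured compounds named here, three measured steps bear on this change. Exchanging the (2-hydroxyethyl)carbonyl of compound 1 for 2-methoxybutyl gave a 1.1-fold lower number from compound 1 to compound 3 (0.03 log units; within the scatter), and exchanging it for 2-methoxyethyl gave a 1.1-fold lower number from compound 1 to compound 2 (0.03 log units; within the scatter). Adding ethyl gave a 1.0-fold higher number from compound 2 to compound 3 (0.01 log units; within the scatter). All three stayed within the scatter, so swapping this group has so far left the number in place. Going by the values given here, none of the measured compounds has a ring in this group, however, so the furan-3-yl itself is untested and the uncertainty is wide, mostly towards lower numbers.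

The expected change is a 1.3-fold lower number from compound 3 to compound 4 (0.10 log units; within the scatter), which would not exceed the scatter. For compound 4 the estimated value is 50000 nM, with an expected range from 15000 nM to 90000 nM.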

Compound 4, half-maximal inhibitory concentration: > 100000 nM
Compound 4: no number, only a limit (the forecaster's own chance of this, stated with the estimate: 10%); at least 2.0-fold (0.30 log units) between middle value and limit.
By their numbers in this assay, from the lowest: compounds 2, 3 and 1 (each within the scatter of the next). At a limit, above all of these: compound 4.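

In this assay compound 4 gives no number, only a limit of the assay: the limit of > 100000 nM in this assay, at which 1 of the 4 values shown sits.

For the compounds shown here, this is the first compound in the set that cannot be placed beside the others, whereas the earlier exchanges on this oxygen all stayed within the scatter. The steps read an at least 1.5-fold higher number from compound 3 to compound 4 (0.19 log units; that floor lies within the scatter) and an at least 1.6-fold higher number from compound 2 to compound 4 (0.20 log units; that floor lies within the scatter) and also an at least 1.4-fold higher number from compound 1 to compound 4 (0.17 log units; that floor lies within the scatter), so each shows only a floor, and none of these floors establishes a change beyond the scatter. Compound 1 carries a carbonyl on the same oxygen, so the step from it isolates furan-3-yl in place of 2-hydroxyethyl on a carbonyl carbon, and the carbonyl alone does not set compound 4 apart.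

On these data alone, how far the true number of compound 4 lies from the other three stays open, and the step could turn out small or large. As far as these compounds go, whether this outcome belongs to the furan-3-yl ring in particular or to any ring on that carbonyl also stays open, since only a comparison with benzoyl or (tetrahydrofuran-3-yl)carbonyl on the same oxygen could separate those readings.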